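The compounds below may be only part of what the source reports. "The series", "measured", "known", "first", "only" and "open" are said of these compounds alone.

Working notes on a small amide-linked diaryl ether series. Compound 1 `Cc1c(C(=O)Nc2ccc(Oc3ncnc4[nH]cc(-c5ccccc5)c34)c(F)c2)c(=O)c2ccccc2n1C` carries the shared core with hydrogen at the position of interest. In an assay on isolated protein for inhibition of tyrosine-protein kinase receptor UFO (Homo sapiens), read by FRET and Z'-LYTE, with a stated time of 1.5 h (on this read-out higher numbers stand for weaker inhibition and lower numbers for stronger inhibition), compound 1 gives > 10000 nM, which is a limit of the assay and not a number. Compound 2 `CCc1ccc2c(c1)c(=O)c(C(=O)Nc1ccc(Oc3ccnc(C(N)=O)c3Cl)c(F)c1)c(C)n2C` has a different ether-linked heteroaryl part. In this assay compound 2 gives > 10000 nM, again a limit. Both values shown thus sit at the limit of > 10000 nM in this assay, at which 2 of the 2 values shown sit, so compound 1 cannot be ranked against anything measured here; it simply stands at the limit.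

Compound 3 `Cc1c(C(=O)Nc2ccc(Oc3ncnc4[nH]cc(-c5ccccc5)c34)c(F)c2)c(=O)c2cc(OC(F)(F)F)ccc2n1C` differs from compound 1 by trifluoromethoxy in place of hydrogen on an aromatic carbon. Among the measured compounds shown here, no step between measured compounds is known, so nothing in the data points to a gain or a loss in this assay beyond the scatter from this change. Compound 3 is accordingly expected to remain at or near the limit, at about 10000 nM with a range from 3000 nM to 30000 nM. The expected step of a number no higher from compound 1 to compound 3 (the limit leaves the size open) is estimated as essentially none.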

Compound 3, half-maximal inhibitory concentration: 74 nM
Compound 3: middle estimate off by 140-fold (2.13 log units), on the high side, outside the stated range (below it).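

In this assay, the aromatic carbon meta to a fused ring and para to a fused ring proves sensitive to substitution: trifluoromethoxy in place of hydrogen there gives an at least 130-fold lower number from compound 1 to compound 3 (2.13 log units; beyond the scatter). From the compounds shown here alone, the value of compound 1 is a limit, so the full size of this step stays unknown. Compound 3 is the only compound shown that does not sit at the limit: the limit of > 10000 nM in this assay, at which 2 of the 3 values shown sit.

Going by these compounds, how a methoxy, a chlorine, a trifluoromethyl or an amine on the same carbon would compare with trifluoromethoxy stays open, so the data do not show which feature of the group matters. Also open, on these data alone, is whether the step carries over to other ether-linked heteroaryl parts; compound 2 differs from compound 1 in more than one place and offers no comparison.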